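This account rests on a few compounds, and the source may have more. Where it says the series, first, only, none or still open, it means among the compounds named here.

Compound 1 `O=C(O)/C(S)=C/c1c[nH]c2cc(Cl)ccc12` is tested in an assay on isolated protein for inhibition of Calpain-1 catalytic subunit (Sus scrofa), read by FRET (on this read-out higher numbers stand for weaker inhibition and lower numbers for stronger inhibition), and gives 210 nM. Among the three compounds measured so far, compound 1 stands second highest. Compound 3 `O=C(O)/C(S)=C/c1c[nH]c2c(F)cccc12` gives 120 nM in this assay, a number within the scatter of that of compound 1. Compound 2 `O=C(O)/C(S)=C/c1ccccc1Cl` gives 11900 nM in this assay, far beyond the scatter from compound 1, and is the weakest inhibitor of the three. Compound 4 `O=C(O)/C(S)=C/c1c[nH]c2cc(I)ccc12` has not yet been measured; it differs from compound 1 by iodo in place of chloro on an aromatic carbon. Among the compounds with values here, no pair of measured compounds shows what this exchange does, so in this assay the expected step is a 1.4-fold lower number from compound 1 to compound 4 (0.15 log units; within the scatter), which would stay within the scatter. Compound 4 is therefore expected to give 150 nM, with a range from 60 nM to 400 nM.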

Compound 4, half-maximal inhibitory concentration: 170 nM
Beside the measured number, compound 4's estimate is 1.1-fold (0.05 log units) below it, within the range that was stated.
By their numbers in this assay, from the lowest: compounds 3, 4 and 1 (each within the scatter of the next); then compound 2.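

In this assay, iodo in place of chloro on this aromatic carbon of the six-membered ring gives a 1.2-fold lower number from compound 1 to compound 4 (0.09 log units; within the scatter) and so does not separate the two halogens. This carbon of the shared core therefore accepts either chloro or iodo with no change beyond the scatter. Nothing measured on these compounds offers a reason for this. Still open, on these data alone, is what a group other than a halogen, such as an amine, a methoxy or a carboxylic acid, would do at this carbon. As far as these compounds go, whether the exchange behaves alike at other ring carbons is also open.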